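The source may report more compounds than this note shows. Statements on the series, on what has been measured and on what is new or still open speak of the compounds shown alone.

Working notes on the series. In a functional assay on KBVIN cells (Homo sapiens) for cytotoxicity, read by MTT assay, with a stated time of 72 h (on this read-out lower numbers stand for an effect already at smaller amounts and higher numbers for an effect only at larger amounts of compound), compound 1 `CCc1cccc2c(OC)c(-c3occ(C)c3C(=O)OC)ccc12` gives 1.3 ug/mL and compound 2 `CCOC(=O)c1c(C)coc1-c1ccc2c(CC)cccc2c1OC` gives 1.8 ug/mL. Among the compounds with values here, these are the only two numbers so far, and they lie within the scatter of each other. Compound 3 `CCc1cccc2c(OC(C)=O)c(-c3occ(C)c3COC(C)=O)ccc12` is reported only as a limit, > 10 ug/mL.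

Compound 4 `CCOCc1c(C)coc1-c1ccc2c(CC)cccc2c1OC` carries ethoxymethyl in place of methoxycarbonyl on an aromatic carbon. Within the data shown here, the one measured step in a single place is a 1.4-fold higher number from compound 1 to compound 2 (0.14 log units; within the scatter). That step keeps the carbonyl, so it gives no direct size for this change. Compound 3 also lacks methoxycarbonyl but differs from compound 1 in more than one place, so its limit cannot be assigned to either change. It still tilts the expectation towards a higher number in this assay, modest in size but uncertain. The expected step is a 2.3-fold higher number from compound 1 to compound 4 (0.36 log units; beyond the scatter). For compound 4 the estimate is 3 ug/mL, with an expected range of 1.2 ug/mL to 9 ug/mL.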

Compound 4, concentration for half-maximal effect: > 10 ug/mL
Compound 4: a limit, no number; the forecaster's own chance of this, stated with the estimate: 15%; middle value at least 3.3-fold (0.52 log units) from the limit.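

In this assay compound 4 is reported only as a limit, > 10 ug/mL: the limit of > 10 ug/mL in this assay, at which 2 of the 4 values shown sit.

Exchanging methoxycarbonyl for ethoxymethyl gives an at least 7.6-fold higher number from compound 1 to compound 4 (0.88 log units; beyond the scatter), and exchanging ethoxycarbonyl for ethoxymethyl gives an at least 5.5-fold higher number from compound 2 to compound 4 (0.74 log units; beyond the scatter), whereas the change within the carbonyl-bearing group gave only a 1.4-fold higher number from compound 1 to compound 2 (0.14 log units; within the scatter). Among compounds 1, 2 and 4, this aromatic carbon of the five-membered ring therefore responds to removal of the carbonyl-bearing group, while the alkyl part of that group makes no difference beyond the scatter.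

Going by these compounds, the true size of both new steps stays open, since compound 4 gives no number. Whether the carbonyl itself accounts for the change also remains open: a carboxylic acid, a primary amide or a hydroxymethyl group at this place would help to settle it.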